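Fluoro on the phenyl of compound 1

The compounds below may be only part of what the source reports. "The series", "measured", "known", "first", "only" and "open" are said of these compounds alone.

Compound 1 `CCC(C(=O)N1CCN(c2ccccc2)CC1)N1C(=O)CCC1=O` stands highest of the two numbers measured in a functional assay on the whole organism (strain Swiss) with Mus musculus as the target, in the maximal electroshock model, with a stated time of 0.5 h, at a dose of 300 mg/kg by the intraperitoneal route (a lower number here means a weaker effect, a higher number a stronger effect of the compound at the dose given), giving 75%. Compound 2 `CCC(C(=O)N1CCN(c2ccccc2C(F)(F)F)CC1)N1C(=O)CCC1=O` gives 25%, a step of a number 50 percentage points lower from compound 1 to compound 2 (beyond the scatter). Compound 3 `CCC(C(=O)N1CCN(c2cccc(F)c2)CC1)N1C(=O)CCC1=O` carries fluoro in place of hydrogen on an aromatic carbon. Within the data shown here, the only measured step that bears on this change is the trifluoromethyl one, which was large and downward; with fluoro entering in place of hydrogen a fall is expected, but a smaller one. The expected step is a number 20 percentage points lower from compound 1 to compound 3 (beyond the scatter). Compound 3 is therefore estimated at 55%, with a range from 30% to 80%.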

Compound 3, a percentage reported as activity, at one dose (the size of the read-out at that dose, not a potency): 100%
Beside the measured number, compound 3's estimate is 45 percentage points below it; measured number above the stated range.
By their numbers in this assay, from the lowest: compound 2; then compound 1; then compound 3.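

Substitution on the phenyl need not lower the read-out: going from phenyl to 3-fluorophenyl gives a number 25 percentage points higher from compound 1 to compound 3 (beyond the scatter) in this assay, the only upward step shown, and opposite in direction to a number 50 percentage points lower from compound 1 to compound 2 (beyond the scatter). A single fluoro meta to a large group is therefore tolerated on the aromatic ring at this dose. No measurement available here accounts for the rise.

As far as these compounds go, it remains open whether the gain is specific to fluoro or to this place on the ring. Chloro or methoxy at the same place could separate these two readings.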